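The compounds below may be only part of what the source reports. "The series", "measured", "known", "first", "only" and "open" are said of these compounds alone.

In a functional assay on K562 cells (Homo sapiens) for antiproliferative activity, read by MTT assay, with a stated time of 48 h (on this read-out higher numbers stand for weaker inhibition and lower numbers for stronger inhibition), compound 2 `CN(C)CCn1c(N)c(-c2nc3ccccc3n2C)c2nc(C#N)c(C#N)nc21` reads > 50000 nM, which is a limit of the assay and not a number. Compound 3 `CN(C)CCCn1c(N)c(-c2nc3ccccc3n2C)c2nc(C#N)c(C#N)nc21` differs from compound 2 by one change, ((dimethylamino)methyl in place of dimethylamino on a saturated chain carbon, two bonds along the chain from an aromatic nitrogen), which turns 2-(dimethylamino)ethyl into 3-(dimethylamino)propyl. Compound 1 `CN(C)CCCn1c(N)c(-c2nc3ccccc3[nH]2)c2nc(C#N)c(C#N)nc21`, which also carries 3-(dimethylamino)propyl, gives 1730 nM in this assay, so some move toward stronger inhibition is expected. The expected size of this move is an at least 3.3-fold lower number from compound 2 to compound 3 (0.52 log units; beyond the scatter). For compound 3 the estimated value is 15000 nM, with an expected range of 4000 nM to 50000 nM.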

Compound 3, half-maximal inhibitory concentration: 3560 nM
For compound 3 the middle estimate is 4.2-fold (0.62 log units) above the measured one, and the stated range ends above it.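

In this assay, 3-(dimethylamino)propyl in place of 2-(dimethylamino)ethyl gives an at least 14-fold lower number from compound 2 to compound 3 (1.14 log units; beyond the scatter). That step is only a lower bound on the change, since compound 2 stands at a limit of the assay: the limit of > 50000 nM in this assay, at which 1 of the 3 values shown sits.

Methyl in place of hydrogen on an aromatic nitrogen is the smaller change, giving a 2.1-fold higher number from compound 1 to compound 3 (0.31 log units; beyond the scatter).

Going by these compounds, it remains open whether the chain step would hold with hydrogen on that aromatic nitrogen. Also open, on these data alone, is how a longer chain, or morpholine in place of dimethylamino, would read.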